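The source may report more compounds than this note shows. Statements on the series, on what has been measured and on what is new or still open speak of the compounds shown alone.

The measured compounds, each with its value in a functional assay on HCT-116 cells (Homo sapiens), read by MTT assay, with a stated time of 72 h; on this read-out lower numbers stand for stronger inhibition and higher numbers for weaker inhibition:

compound 1 `O=c1[nH]cnc2c1c(-c1ccoc1)cn2[C@@H]1O[C@H](CO)[C@@H](O)[C@H]1O`: 14800 nM
compound 2 `COc1ncnc2c1c(-c1ccoc1)cn2[C@@H]1O[C@H](CO)[C@@H](O)[C@H]1O`: 130 nM
compound 3 `COc1nc(N)nc2c1c(-c1ccccc1)cn2[C@@H]1O[C@H](CO)[C@@H](O)[C@H]1O`: a limit of this assay, > 20000 nM

Of the two numbers given, compound 1 carries the higher one, with a gap to compound 2 that lies well beyond the scatter. The value of compound 3 is a limit of this assay and not a number; its structure differs from compound 1 in more than one place, so what is shown only says that compound 3 gives no number at all.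

Compound 4 `O=c1[nH]cnc2c1c(-c1ccsc1)cn2[C@@H]1O[C@H](CO)[C@@H](O)[C@H]1O` differs from compound 1 in a single place: thiophen-3-yl in place of furan-3-yl on an aromatic carbon. Within the data shown here, no measured pair shows this same change, so no step of this kind is known. A change of this size, exchanging one five-membered aromatic ring for another that counts the same heavy atoms and acceptors, is expected to move the number little in this assay, if at all, and any movement is expected to remain within the scatter, with the step of a 1.2-fold lower number from compound 1 to compound 4 (0.09 log units; within the scatter) as the expected outcome. On that basis compound 4 is estimated to give 12000 nM in this assay, with the expected range running from 4000 nM to 36000 nM; an outcome that only reaches the limit of this assay cannot be ruled out.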

Compound 4, half-maximal inhibitory concentration: > 20000 nM
Compound 4 gave a limit, no number (the forecaster's own chance of this, stated with the estimate: 25%); middle value at least 1.6-fold (0.22 log units) away from the limit.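

In this assay compound 4 gives > 20000 nM, which is a limit of the assay and not a number. Among these compounds, this is the first reading of a change at this aromatic carbon: thiophen-3-yl in place of furan-3-yl gives an at least 1.3-fold higher number from compound 1 to compound 4 (0.13 log units; that floor lies within the scatter), so the exchange brings no lower number on this core, while the true size of the step stays unknown. The limit is also no isolated end point among the compounds shown: the limit of > 20000 nM in this assay, at which 2 of the 4 values shown sit.

As far as these compounds go, how far the true value of compound 4 lies from that of compound 1 remains open, as does whether thiophen-3-yl would behave the same way on the core of compound 2. Also open, from the compounds shown here alone, is whether a pyridine ring or a small amine on this same carbon would give a lower number than compound 1.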